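The source may hold more compounds than are shown below. What is called first, only, known or untested is meant among the compounds shown, and "the series" means these compounds.

Measured so far in an assay on cells (Hepatocyte) for inhibition of glucokinase regulatory protein (Mus musculus), with stated times of 20 min and 40 min; on this read-out lower numbers stand for an effect already at smaller amounts and higher numbers for an effect only at larger amounts of compound:
Compound 1, `CC#C[C@H]1CN(S(=O)(=O)c2ccc(N)nc2)CCN1c1ncc(C(C)(O)C(F)(F)F)s1`: > 12500 nM, a limit of the assay.
Compound 2, `CC#C[C@H]1CN(S(=O)(=O)c2ccc(N)nc2)CCN1c1ccc([C@@](O)(CO)C(F)(F)F)cc1`: 89 nM.
Compound 3, `CC#C[C@H]1CN(S(=O)(=O)c2ccc(N)nc2)CCN1c1ccc(S(=O)(=O)Nc2ccccc2)cc1`: > 12500 nM, a limit of the assay.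

Compound 3 thus stands at a limit in this assay, not at a number. Two of the three values shown sit at that limit (the limit of > 12500 nM in this assay, at which 2 of the 3 values shown sit). Compound 4, `CC#C[C@H]1CN(S(=O)(=O)c2ccc(N)nc2)CCN1c1ccc(S(C)(=N)=O)cc1`, differs from compound 3 in one place: a group of 4 heavy atoms (1 carbon, 1 nitrogen, 1 oxygen, 1 sulfur; no ring) in place of a group of 10 heavy atoms (6 carbon, 1 nitrogen, 2 oxygen, 1 sulfur; one six-membered aromatic ring of carbon only), on an aromatic carbon. Going by the values given here, the one measured step bearing on this position is an at least 140-fold higher number from compound 2 to compound 3 (2.14 log units; beyond the scatter), where a ring-free group on that aromatic carbon gave a number and the phenylsulfamoyl group drove the value past the limit. Compound 4 returns to a small, ring-free group there, so a large fall in the number is expected, though not necessarily all the way back. Compound 4 is therefore estimated at 600 nM, with a range from 120 nM to 5000 nM, an expected step of an at least 20-fold lower number from compound 3 to compound 4 (1.31 log units; beyond the scatter).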

Compound 4, half-maximal effective concentration: 704 nM
Estimate against measurement, compound 4: 1.2-fold (0.07 log units) below; low and high end bracket the measured number.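

In this assay, replacing the phenylsulfamoyl group with a small, ring-free sulfur-bearing group gives an at least 17-fold lower number from compound 3 to compound 4 (1.24 log units; beyond the scatter), so sulfur on this aromatic carbon does not by itself carry the value to the limit. Compound 3 stands at a limit, so that step is a bound only: the limit of > 12500 nM in this assay, at which 2 of the 4 values shown sit. Ring-free groups at this place still differ clearly, with a 7.9-fold higher number from compound 2 to compound 4 (0.90 log units; beyond the scatter).

In the first step, the aromatic ring and the size of the group change together. The compounds shown do not tell these two changes apart. They also leave open whether a methylsulfonyl group or a carboxylic acid on this carbon would fall nearer compound 2 or compound 4.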